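The source may hold more compounds than are shown below. What is called first, only, known or untested is meant among the compounds shown, and "the series" means these compounds.

Measured compounds in an assay on membranes from HeLa cells for displacement of a labelled ligand from adenosine receptor A3 (Homo sapiens), read by scintillation counting, with a stated time of 180 min, tested at 1 uM; on this read-out lower numbers stand for less inhibition and higher numbers for more inhibition at the one concentration tested (going by the name of the read-out):
Compound 1, `CCCOC(=O)C1=C(C)NC(=O)NC1c1ccsc1`: 6%
Compound 2, `CC1=C(C(=O)OCC2CC2)C(c2ccoc2)NC(=O)N1`: 3%
Compound 3, `CCC(CC)OC(=O)C1=C(C)NC(=O)NC1c1ccsc1`: 6%

On these three numbers compound 3 stands level with compound 1, and together they are the highest of the set; compound 2 sits a few points lower, which is within the scatter of this kind of measurement. All three compounds show only slight inhibition at the single concentration tested.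

Going by the values given here, the one step among the measured compounds, no change at the digits printed from compound 1 to compound 3 (within the scatter), shows that enlarging the group on the oxygen next to a carbonyl group left the read-out unchanged. Compound 4, `CC1=C(C(=O)OCC2CC2)C(c2ccsc2)NC(=O)N1`, follows from compound 3 by cyclopropylmethyl in place of pentan-3-yl on an oxygen next to a carbonyl group. Among the compounds with values here, the only measured step at this position bears directly on it, and it was flat. Compound 2 carries the same cyclopropylmethyl group on the oxygen next to a carbonyl group while differing elsewhere in the core, and its value is no higher than that of compound 3.

Compound 4 is therefore expected to show a step of a number 1 percentage points lower from compound 3 to compound 4 (within the scatter) in this assay, that is, nothing beyond the scatter. The estimate for compound 4 is 5%, with a range from 0% to 12%.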

Compound 4, a percentage reported as inhibition, at one concentration (the size of the read-out at that concentration, not a potency): 3%
The estimate for compound 4 lay 2 percentage points above the measured number; measured number inside the range.
By their numbers in this assay, from the lowest: compounds 2, 4, 1 and 3 (each within the scatter of the next).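

In this assay, the replacement of pentan-3-yl by cyclopropylmethyl on an oxygen next to a carbonyl group gives a number 3 percentage points lower from compound 3 to compound 4 (within the scatter), and the replacement of ethyl by cyclopropyl on a saturated chain carbon bound to that oxygen gives a number 3 percentage points lower from compound 1 to compound 4 (within the scatter), so a group carrying a three-membered ring now joins the open-chain groups at this position without a step beyond the scatter. Going by these compounds alone, the result also gives the first reading of a change at a second position with the cyclopropylmethyl group held fixed: thiophen-3-yl in place of furan-3-yl on a saturated ring carbon gives no change at the digits printed from compound 2 to compound 4 (within the scatter), which likewise stays within the scatter. Nothing on hand offers an explanation for these readings.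

The compounds shown leave open whether a benzyl group on the oxygen, a longer chain carrying an amine there, or a phenyl group in place of thiophen-3-yl on the saturated ring carbon would take the read-out beyond the scatter. With every step here inside the scatter, they also leave open whether either position has any bearing on this assay.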